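Working notes: replacing nitro with methyl

The compounds below may be only part of what the source reports. "The series", "measured", "known", "first", "only" and "open" are said of these compounds alone.

Compound 1 `COc1ccc(-c2nnc(SCCCN3CCN(c4nc5ccccc5o4)CC3)o2)cc1` gives 66100 nM
Compound 2 `O=[N+]([O-])c1ccc(-c2nnc(SCCCN3CCN(c4nc5ccccc5o4)CC3)o2)cc1` gives 67200 nM

Both values come from a functional assay on HepG2 cells (Homo sapiens) for inhibition, read by MTT assay, with a stated time of 72 h (on this read-out lower numbers stand for stronger inhibition and higher numbers for weaker inhibition), and lie within the scatter of each other, so compound 2 stands level with compound 1. Next is compound 3 `Cc1ccc(-c2nnc(SCCCN3CCN(c4nc5ccccc5o4)CC3)o2)cc1` with methyl in place of nitro on an aromatic carbon and the rest of the structure unchanged. Going by the values given here, the only measured step bearing on this change is a 1.0-fold higher number from compound 1 to compound 2 (0.01 log units; within the scatter) with nitro in place of methoxy on an aromatic carbon. One step is thin evidence, yet no shift beyond the scatter is expected in this assay here. The expected step is a 1.0-fold lower number from compound 2 to compound 3 (0.01 log units; within the scatter) on this estimate. For compound 3 the estimated value is 66000 nM with an expected range from 35000 nM to 120000 nM in this read-out.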

Compound 3, half-maximal inhibitory concentration: 154000 nM
Compound 3: middle estimate off by 2.3-fold (0.37 log units), on the low side, and the stated range ends below it.
By their numbers in this assay, from the lowest: compounds 1 and 2 (each within the scatter of the next); then compound 3.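

On the aromatic carbon para to a large group, the choice of group does matter in this assay: the change to methyl gives a 2.3-fold higher number from compound 2 to compound 3 (0.36 log units; beyond the scatter) and a 2.3-fold higher number from compound 1 to compound 3 (0.37 log units; beyond the scatter) on the same core. Nitro and methoxy remain level with each other, so the separation appears only with methyl, and compound 3 is the weakest of the three. Nothing measured here accounts for this shift.

As far as these compounds go, whether the shift is particular to methyl stays open. An amine, a carboxylic acid or a longer chain such as ethyl or propyl at this place would help to settle it.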